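Swapping the benzyl group of compound 3

The compounds below may be only part of what the source reports. "The series", "measured", "known", "first", "only" and "open" are said of these compounds alone.

Compound 1, `O=c1ccoc2cc(OCc3cn(Cc4ccc(F)cc4)nn3)ccc12`: in a functional assay on A549 cells (Homo sapiens) for cytotoxicity, read by MTT assay, with a stated time of 48 h (a lower number here means a stronger inhibitor, a higher number a weaker inhibitor), compound 1 gives > 100000 nM, which is a limit of the assay rather than a number.
Compound 2, `O=c1ccoc2cc(OCc3cn(Cc4ccc(Br)cc4)nn3)ccc12`: compound 2 gives > 100000 nM, again only a limit.
Compound 3, `O=c1ccoc2cc(OCc3cn(Cc4ccccc4F)nn3)ccc12`: compound 3 gives 10800 nM.

Going by the values given here, compound 3 therefore holds the only measured number; the other two values sit at the limit of > 100000 nM in this assay, at which 2 of the 3 values shown sit. Compound 4, `COc1ccc(Cn2cc(COc3ccc4c(=O)ccoc4c3)nn2)cc1`, differs from compound 3 by 4-methoxyphenyl in place of 2-fluorophenyl on a saturated chain carbon bound to an aromatic nitrogen. Among the compounds with values here, two measured steps bear on this change: an at least 9.2-fold lower number from compound 1 to compound 3 (0.96 log units; beyond the scatter) and an at least 9.2-fold lower number from compound 2 to compound 3 (0.96 log units; beyond the scatter). Both replaced a 4-fluorophenyl or 4-bromophenyl with the 2-fluorophenyl of compound 3, and both lowered the number. Compound 4 carries a 4-methoxyphenyl rather than a 2-fluorophenyl, resembling compounds 1 and 2 in that respect, so a higher number is expected. For compound 4 the estimate is 80000 nM, within 20000 nM to 300000 nM. The estimate implies the step of a 7.4-fold higher number from compound 3 to compound 4 (0.87 log units; beyond the scatter), and a limit rather than a number is expected more often than not.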

Compound 4, half-maximal inhibitory concentration: 16500 nM
For compound 4 the middle estimate is 4.8-fold (0.69 log units) above the measured one; the whole stated range lies above it.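

In this assay, a number well short of the limit does not depend on the 2-fluorophenyl group: the step of a 1.5-fold higher number from compound 3 to compound 4 (0.18 log units; within the scatter) leaves compound 3 and compound 4 indistinguishable. Among the groups with a single substituent at the same place, methoxy stands apart from bromo and fluoro, with an at least 6.0-fold lower number from compound 2 to compound 4 (0.78 log units; beyond the scatter) and an at least 6.0-fold lower number from compound 1 to compound 4 (0.78 log units; beyond the scatter). Both steps start from a limit of the assay rather than a number: the limit of > 100000 nM in this assay, at which 2 of the 4 values shown sit.

Going by these compounds, how an amine or a carboxylic acid would read in place of the methoxy remains open. So does the effect of a longer chain there.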